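The source may hold more compounds than are shown below. What is called first, only, known or untested is meant among the compounds shown, and "the series" means these compounds.

In a physicochemical assay for solubility, read by HPLC, in phosphate buffer, with a stated time of 24 h, at pH 7.4, tested at 100 uM (a lower number here means a less soluble compound, a higher number a more soluble compound), compound 1 (`CN(C)c1ccc(Nc2c(NCCCCCC(=O)NO)c(=O)c2=O)cc1`) gives 12000000 nM, compound 2 (`COc1ccc(Nc2c(NCCCCCC(=O)NO)c(=O)c2=O)cc1`) gives 3300000 nM and compound 3 (`O=C(CCCCCNc1c(Nc2ccc(C(F)(F)F)cc2)c(=O)c1=O)NO`) gives 4500000 nM. Two steps fix where that last value stands: a 1.4-fold higher number from compound 2 to compound 3 (0.13 log units; within the scatter), and a 2.7-fold lower number from compound 1 to compound 3 (0.43 log units; beyond the scatter). Compound 4 (`CC(CCCCC(=O)NO)Nc1c(Nc2ccc(C(F)(F)F)cc2)c(=O)c1=O`) has methyl in place of hydrogen on a saturated chain carbon bound to a nitrogen on an aromatic ring and a saturated chain carbon. For the measured compounds named here, no measured step touches that chain. All three concern the group on an aromatic carbon, the largest being a 3.6-fold lower number from compound 1 to compound 2 (0.56 log units; beyond the scatter), so they offer only a scale. No step beyond the scatter is expected in this assay. The expected step is a 1.1-fold lower number from compound 3 to compound 4 (0.05 log units; within the scatter). Compound 4 is estimated at 4000000 nM, with an expected range of 2000000 nM to 8000000 nM.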

Compound 4, solubility: 30000000 nM
Compound 4: middle estimate off by 7.5-fold (0.88 log units), on the low side; the measured number lies above the stated range.
By their numbers in this assay, from the lowest: compounds 2 and 3 (each within the scatter of the next); then compound 1; then compound 4.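

In this assay, the saturated chain carbon bound to a nitrogen on an aromatic ring and a saturated chain carbon proves a sensitive position: methyl in place of hydrogen there gives a 6.7-fold higher number from compound 3 to compound 4 (0.82 log units; beyond the scatter). For the compounds shown here, this chain position, untouched by the earlier steps, moves the number on the same scale as changes on an aromatic carbon, such as a 3.6-fold lower number from compound 1 to compound 2 (0.56 log units; beyond the scatter). No measurement shown explains the rise. From the compounds shown here alone, whether it carries over to the methoxy or dimethylamino aromatic groups stays open, as does the outcome with ethyl or an amine at this chain carbon.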